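This account rests on a few compounds, and the source may have more. Where it says the series, first, only, none or still open, it means among the compounds named here.

Compound 2 `Cc1cc(NC(=O)Nc2ccc(N)cc2)c2ccccc2n1` belongs to a small set sharing one core. In an ADME assay on HepG2 cells (Homo sapiens) for cytotoxicity, with a stated time of 72 h (on this read-out higher numbers stand for an effect only at larger amounts of compound and lower numbers for an effect already at smaller amounts), compound 2 gives only a limit, > 25000 nM. Compound 1 `Cc1cc(NC(=O)Nc2ncccc2C)c2ccccc2n1` likewise gives a limit in this assay, > 25000 nM. Compound 3 `Cc1cc(NC(=O)Nc2ccccc2F)c2ccccc2n1` also gives a limit there, > 25000 nM. All of the measured compounds thus stand at the limit of > 25000 nM in this assay, at which 3 of the 3 values shown sit. The steps a step that the two limits leave unreadable from compound 1 to compound 2, a step that the two limits leave unreadable from compound 1 to compound 3 and a step that the two limits leave unreadable from compound 2 to compound 3 therefore cannot be read, and none of them gives a direction. Compound 4 `Cc1cc(NC(=O)Nc2ccc(C(F)(F)F)cc2)c2ccccc2n1` differs from compound 2 by trifluoromethyl in place of amino on an aromatic carbon. With no readable step to rest on, compound 4 is expected to stay at or near the same limit in this assay, estimated at 40000 nM, between 15000 nM and 100000 nM. The step that the limit leaves unreadable from compound 2 to compound 4 is accordingly expected to lie within the scatter.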

Compound 4, half-maximal effective concentration: 23000 nM
Estimate against measurement, compound 4: 1.7-fold (0.24 log units) above; the range from low to high includes it.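

Among the compounds shown here, with trifluoromethyl in place of amino on this aromatic carbon, para to a large group, this assay gives the first step with a readable floor, an at least 1.0-fold lower number from compound 2 to compound 4 (0.03 log units; that floor lies within the scatter). From the compounds shown here alone, the true size of this step stays unknown, and the floor gives no evidence of a change beyond the scatter. Compound 4 is the only compound here with a value that is not a limit, and the others stay where they stood: the limit of > 25000 nM in this assay, at which 3 of the 4 values shown sit.

Going by these compounds, whether a methoxy group or a carboxylic acid at this place would also give a number remains open. On these data alone, it is also open whether trifluoromethyl would do so on the other aromatic rings.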